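Swapping furan for pyrrole on a fused thiadiazole-type core

The source may report more compounds than this note shows. Statements on the series, on what has been measured and on what is new or still open speak of the compounds shown alone.

Of the compounds shown here, three have been tested in a functional assay on the whole organism (strain Wistar Albino) for inhibition, with Rattus norvegicus as the target, read by paw edema, with a stated time of 1 h, at a dose of 20 mg/kg; a lower number here means less inhibition, a higher number more inhibition at the dose given (going by the name of the read-out). Compound 1 `COc1ccc(Cl)c(-c2nnc3n2NC(c2ccco2)S3)c1` gives 13.9%, compound 2 `Cc1occc1-c1nnc2n1NC(c1ccco1)S2` gives 16.4%, and compound 3 `COc1ccc(Cl)c(-c2nnc3n2NC(c2ccc[nH]2)S3)c1` gives 12.8%; all three lie within the scatter of one another, so no order among them can be read. Compound 3 differs from compound 1 by one change, (1H-pyrrol-2-yl in place of furan-2-yl on a saturated ring carbon), and this change made the step of a number 1.1 percentage points lower from compound 1 to compound 3 (within the scatter). The difference between the core of compound 1 and the core of compound 2 is not broken down here. Compound 4 `Cc1occc1-c1nnc2n1NC(c1ccc[nH]1)S2` is not yet measured; it carries the same change as compound 3, (1H-pyrrol-2-yl in place of furan-2-yl on a saturated ring carbon), now made on compound 2. Because the measured step of a number 1.1 percentage points lower from compound 1 to compound 3 (within the scatter) was within the scatter, the step from compound 2 to compound 4 is expected to be small, a number 1.1 percentage points lower from compound 2 to compound 4 (within the scatter). Compound 4 is therefore estimated at 15.3% in this assay, between 9.5% and 21%.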

Compound 4, a percentage reported as inhibition, in the whole organism at one dose (the size of the read-out at that dose, not a potency): 13.7%
Compound 4: middle estimate off by 1.6 percentage points, on the high side, and the stated range covers the measured number.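

In this assay, putting 1H-pyrrol-2-yl in place of furan-2-yl on the saturated ring carbon gives a number 2.7 percentage points lower from compound 2 to compound 4 (within the scatter) and the step on this second core matches the earlier one: the same change on two cores in this assay, a number 1.1 percentage points lower (within the scatter) from compound 1 to compound 3 and a number 2.7 percentage points lower (within the scatter) from compound 2 to compound 4, 1.6 percentage points apart, within the scatter of two such steps. The change therefore carries over between these two cores with no difference that can be told from scatter. It does not show that the change truly shifts the inhibition on either core, nor how it would behave on any other core.

The compounds shown carry only furan-2-yl or 1H-pyrrol-2-yl at this place, so what a phenyl ring, an amine or a carboxylic acid would give there stays open. Going by these compounds, how these compounds compare at other doses or times also stays open.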